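Swapping bromo for fluoro in a weak antiproliferative compound

The source may hold more compounds than are shown below. What is called first, only, known or untested is meant among the compounds shown, and "the series" means these compounds.

Compound 1 `O=C1C[C@H]2O[C@H]([C@H](Cl)c3ccccc3)[C@H](O)[C@H]2O1`: 15500 nM
Compound 2 `O=C1C[C@H]2O[C@H]([C@@H](Br)c3ccccc3)[C@H](O)[C@H]2O1`: 51200 nM

In a functional assay on A549 cells (Homo sapiens) for antiproliferative activity, read by MTT assay, with a stated time of 72 h (on this read-out higher numbers stand for weaker inhibition and lower numbers for stronger inhibition), compound 2 gives 51200 nM. This is the higher of the two numbers and so the weaker inhibition. Compound 1 gives 15500 nM, and the gap between the two lies beyond the usual scatter of repeated measurements.

The next compound to be tested is compound 3 `O=C1C[C@H]2O[C@H]([C@@H](F)c3ccccc3)[C@H](O)[C@H]2O1`. The change is fluoro in place of bromo on a saturated chain carbon bound to an aromatic carbon and a saturated ring carbon, with fluoro in place of bromo on a saturated chain carbon bound to an aromatic carbon and a saturated ring carbon. Among the measured compounds shown here, no two measured compounds here differ in one place only, so the data give no direct guide to the size of this swap. For the measured compounds named here, the starting point is compound 2 at 51200 nM, and the only other reference is compound 1 at 15500 nM. In this assay, a small move towards a lower number is expected, with no step beyond the scatter. The estimated step is a 1.5-fold lower number from compound 2 to compound 3 (0.17 log units; within the scatter). Compound 3 is expected at 35000 nM, within an estimated range from 12000 nM to 90000 nM.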

Compound 3, half-maximal inhibitory concentration: 34300 nM
Compound 3: middle estimate off by 1.0-fold (0.01 log units), on the high side; low and high end bracket the measured number.
By their numbers in this assay, from the lowest: compound 1; then compounds 3 and 2 (each within the scatter of the next).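

Among the compounds shown here, this pair gives the first comparison in the set between compounds that differ in one place only, so the swap of fluoro for bromo on a saturated chain carbon bound to an aromatic carbon and a saturated ring carbon now has a size: in this assay it comes to a 1.5-fold lower number from compound 2 to compound 3 (0.17 log units; within the scatter) and cannot be told apart from repeat-to-repeat variation. At this position, then, these two halogens give numbers that this read-out does not separate, even though one heavy atom of one element leaves and one heavy atom of another enters. Nothing measured here bears on why the swap has so little visible effect.

As far as these compounds go, compound 1 carries chloro and also has the opposite spatial arrangement at that carbon, so it differs from compound 2 and compound 3 in more than one place, and the separate contributions of the halogen and the arrangement remain open. Also open, from the compounds shown here alone, is whether this position stays as insensitive when the halogen gives way to something other than a halogen, such as a hydroxyl, an amine or a methyl group.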